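Working notes: replacing the carbonyl substituent of compound 3

The source may report more compounds than this note shows. Statements on the series, on what has been measured and on what is new or still open speak of the compounds shown alone.

Measured so far in an ADME assay on HepG2 2.2.15 cells (Homo sapiens) for cytotoxicity; a lower number here means that less compound is tolerated, a higher number that more compound is tolerated:
compound 1 `CCCCCCCC(=O)OCCc1c(-c2ccccc2Cl)c2cc(Cl)ccc2[nH]c1=O`: 78000 nM
compound 2 `O=C(O)CCCC(=O)OCCc1c(-c2ccccc2Cl)c2cc(Cl)ccc2[nH]c1=O`: 110000 nM
compound 3 `CC12CCC(C(=O)OCCc3c(-c4ccccc4Cl)c4cc(Cl)ccc4[nH]c3=O)(OC1=O)C2(C)C`: > 1800000 nM

Compound 3 gives only a limit of the assay and no number, > 1800000 nM. This is the limit of > 1800000 nM in this assay, at which 1 of the 3 values shown sits. The other two compounds differ little, with a 1.4-fold higher number from compound 1 to compound 2 (0.15 log units; within the scatter). Both steps into compound 3 are large: an at least 23-fold higher number from compound 1 to compound 3 (1.36 log units; beyond the scatter), and an at least 16-fold higher number from compound 2 to compound 3 (1.21 log units; beyond the scatter).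

The next compound is compound 4 `O=C(OCCc1c(-c2ccccc2Cl)c2cc(Cl)ccc2[nH]c1=O)c1cccs1`, which keeps the shared core. The change is a group of 5 heavy atoms (4 carbon, 1 sulfur; one five-membered aromatic ring with 1 hetero atom) in place of a group of 11 heavy atoms (9 carbon, 2 oxygen; one five-membered non-aromatic ring of carbon only, one five-membered non-aromatic ring with 1 hetero atom), on a carbonyl carbon, so thiophen-2-yl enters on a carbonyl carbon. Going by the values given here, no measured compound carries thiophen-2-yl, and the group that leaves occurs only in compound 3. The other two compounds, which lack that group, therefore serve as the closest guide. Compound 1 gives 78000 nM, and compound 2 gives 110000 nM. With an at least 23-fold higher number from compound 1 to compound 3 (1.36 log units; beyond the scatter) and an at least 16-fold higher number from compound 2 to compound 3 (1.21 log units; beyond the scatter) as the measured sizes, a large step to a lower number is expected in this assay, of about the same size in reverse. The step expected is an at least 18-fold lower number from compound 3 to compound 4 (1.25 log units; beyond the scatter). The estimate for compound 4 is 100000 nM, with an expected range from 30000 nM to 400000 nM.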

Compound 4, half-maximal cytotoxic concentration: > 1700000 nM
Compound 4: no number, only a limit (the forecaster's own chance of this, stated with the estimate: 15%); at least 17-fold (1.23 log units) between middle value and limit.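

Compound 4 also gives only a limit of the assay and no number in this assay, so reaching a limit on this carbonyl carbon is not confined to the group carried by compound 3: the limit of > 1700000 nM in this assay, at which 1 of the 4 values shown sits.

Thiophen-2-yl in place of heptyl gives an at least 21-fold higher number from compound 1 to compound 4 (1.33 log units; beyond the scatter), and thiophen-2-yl in place of 3-carboxypropyl gives an at least 15-fold higher number from compound 2 to compound 4 (1.18 log units; beyond the scatter). Among these four compounds, the two groups with a ring both end at a limit and the two groups without a ring both give numbers, with no compound going against this, while the step between the two limits cannot be read.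

The compounds shown leave open how compound 3 and compound 4 compare, since neither has a number in this assay. They also leave open whether the ring itself goes with the limit: a phenyl or cyclohexyl group, set against a short chain such as methyl on the same carbonyl carbon, would separate ring from chain length.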